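The compounds below may be only part of what the source reports. "The series", "measured", "known", "first", "only" and "open" are said of these compounds alone.

Values in an in vitro ADME assay on microsomes from liver (Homo sapiens) for metabolic stability; a higher number here means that the compound lasts longer, a lower number that the compound disappears faster:
compound 1 `CC(C)OCC1n2cncc2CN([C@@H](C)c2ccc(Cl)cc2)S1(=O)=O`: 0.0833 h
compound 2 `C[C@@H](c1ccc(Cl)cc1)N1Cc2cncn2C(C[C@H](O)c2ccccc2)S1(=O)=O`: 0.25 h

Of these two numbers, compound 2 holds the higher, and compound 1 lies beneath it by more than the scatter. Compound 3 `COC(C)(C)CC1n2cncc2CN([C@@H](C)c2ccc(Cl)cc2)S1(=O)=O` has not yet been measured in this assay. It differs from compound 2 as follows: 1-methoxy-1-methylethyl in place of hydroxy(phenyl)methyl on a saturated chain carbon bound to a saturated ring carbon. Thus 1-methoxy-1-methylethyl stands in place of hydroxy(phenyl)methyl on a saturated chain carbon bound to a saturated ring carbon. Among the measured compounds shown here, only one measured step bears on this change: a 3.0-fold higher number from compound 1 to compound 2 (0.48 log units; beyond the scatter). That modest step came with hydroxy(phenyl)methyl entering in place of isopropoxy. The change to compound 3 removes hydroxy(phenyl)methyl again and brings in another group with no ring and no hydrogen-bond donor. A modest step in the opposite direction, towards a lower number in this assay, is therefore expected. For the measured compounds named here, no measured compound carries 1-methoxy-1-methylethyl itself, so this expectation remains loose. The estimated change is a 2.1-fold lower number from compound 2 to compound 3 (0.32 log units; beyond the scatter). For compound 3 the expected half-life is 0.12 h, with an estimated range of 0.06 h to 0.25 h.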

Compound 3, half-life: 0.2 h
Beside the measured number, compound 3's estimate is 1.7-fold (0.22 log units) below it; measured number inside the range.
By their numbers in this assay, from the lowest: compound 1; then compounds 3 and 2 (each within the scatter of the next).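

In this assay, the step from the hydroxy(phenyl)methyl group to 1-methoxy-1-methylethyl (a 1.3-fold lower number from compound 2 to compound 3 (0.10 log units; within the scatter)) shows that at this place, on a saturated chain carbon bound to a saturated ring carbon, compound 2 and compound 3 stand level, although the group in compound 3 has no ring and no hydrogen-bond donor. The comparison with isopropoxy (a 2.4-fold higher number from compound 1 to compound 3 (0.38 log units; beyond the scatter)) shows that a rise over compound 1 does not require the six-membered aromatic ring or the hydroxy hydrogen, which the earlier pair could not separate from the change as a whole. The data available give no explanation for either step.

The compounds shown leave open which part of 1-methoxy-1-methylethyl goes with the rise over compound 1, since the methoxy oxygen and the two methyl groups enter together, and a plain tert-butyl group would speak to that. They also leave open how an amine or a carboxylic acid at this same place would read in this assay, as all three groups shown here carry a neutral oxygen.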